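Furanyl in Place of Chlorophenyl at the Saturated Ring Carbon

This account rests on a few compounds, and the source may have more. Where it says the series, first, only, none or still open, it means among the compounds named here.

Compound 3 `CC1=NC(C)=C(C(=O)O)C(c2cccc(Cl)c2)/C1=C(\O)OC/C=C/c1ccccc1` gives 20 nM in a functional assay on thoracic aorta for inhibition of Voltage-gated L-type calcium channel (Rattus norvegicus) (on this read-out lower numbers stand for stronger inhibition and higher numbers for weaker inhibition), the lowest number of the three measured; compound 1 `CC1=NC(C)=C(C(=O)O)C(c2ccc([N+](=O)[O-])cc2)/C1=C(\O)OC/C=C/c1ccccc1` gives 1600 nM and compound 2 `COC(=O)c1cccc(C2C(C(=O)O)=C(C)N=C(C)/C2=C(/O)OC/C=C/c2ccccc2)c1` gives 4400 nM. Compound 4 `CC1=NC(C)=C(C(=O)O)C(c2ccoc2)/C1=C(\O)OC/C=C/c1ccccc1` differs from compound 3 in that (furan-3-yl in place of 3-chlorophenyl on a saturated ring carbon). For the measured compounds named here, the measured steps at this position are an 80-fold lower number from compound 1 to compound 3 (1.90 log units; beyond the scatter) and a 220-fold lower number from compound 2 to compound 3 (2.34 log units; beyond the scatter); both are large, so exchanges at this saturated ring carbon have shifted the number widely, yet none of the measured groups is a five-membered ring. In the absence of a direct precedent, a higher number than compound 3 is expected, the step being estimated as a 15-fold higher number from compound 3 to compound 4 (1.18 log units; beyond the scatter). Compound 4 is therefore estimated at 300 nM, within a range of 60 nM to 1500 nM.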

Compound 4, half-maximal inhibitory concentration: 130 nM
Compound 4: middle estimate off by 2.3-fold (0.36 log units), on the high side, and the stated range covers the measured number.
By their numbers in this assay, from the lowest: compound 3; then compound 4; then compound 1; then compound 2.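

In this assay, furan-3-yl on the saturated ring carbon falls short of 3-chlorophenyl (a 6.5-fold higher number from compound 3 to compound 4 (0.81 log units; beyond the scatter)) but gives a lower number than either 4-nitrophenyl (a 12-fold lower number from compound 1 to compound 4 (1.09 log units; beyond the scatter)) or 3-(methoxycarbonyl)phenyl (a 34-fold lower number from compound 2 to compound 4 (1.53 log units; beyond the scatter)). A six-membered aromatic ring at this position is therefore not needed for a number below those of compound 1 and compound 2. Nothing at hand accounts for this order.

On these data alone, whether furan-2-yl or thiophen-3-yl would come closer to compound 3 remains open. So does the effect of a chloro group on the furan ring of compound 4.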